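Swapping methylselanyl for sulfanyl on the shared core

A few compounds are considered here, and "the series" means these few. Any claim that something is new, unique, unknown or untested is made for them only; others in the source may bear on it.

Measured in an ADME assay on 184B5 cells (Homo sapiens) for cytotoxicity, read by MTT assay, with a stated time of 72 h; on this read-out lower numbers stand for stronger inhibition of growth and higher numbers for weaker inhibition of growth:
compound 1, `COc1ccc(CNc2nc([Se]C)nc3ccccc23)cc1`: > 100000 nM
compound 2, `C[Se]c1nc(NCc2ccccc2)c2ccccc2n1`: 12400 nM
compound 3, `CSc1ccc(CNc2nc([Se]C)nc3ccccc23)cc1`: > 100000 nM

Compound 1 does not have a number in this assay but only a limit, > 100000 nM, and (the limit of > 100000 nM in this assay, at which 2 of the 3 values shown sit). Compound 2 gives 12400 nM. Compound 3 likewise sits at a limit, > 100000 nM.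

Compound 4, `COc1ccc(CNc2nc(S)nc3ccccc23)cc1`, differs from compound 1 in one place: one sulfur atom in place of a group of 2 heavy atoms (1 carbon, 1 selenium; no ring), on an aromatic carbon. The measured steps are an at least 8.0-fold lower number from compound 1 to compound 2 (0.90 log units; beyond the scatter), a step that the two limits leave unreadable from compound 1 to compound 3 and an at least 8.0-fold higher number from compound 2 to compound 3 (0.90 log units; beyond the scatter). All three concern the methoxy group on the other ring and leave the methylselanyl group untouched, so none of them speaks directly to the change toward compound 4. Going by these compounds, since compound 1 itself offers only a limit, the starting point is unknown, and the expected step of a number no higher from compound 1 to compound 4 (the limit leaves the size open) is correspondingly uncertain. Compound 4 is therefore expected to land near 100000 nM, estimated within 20000 nM to 300000 nM, with a fair chance that this assay again reports only a limit.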

Compound 4, concentration for total growth inhibition: 36600 nM
Compound 4: the middle estimate sits 2.7-fold (0.44 log units) above what was measured, within the range that was stated.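

In this assay, sulfanyl in place of methylselanyl, on the aromatic carbon between two ring nitrogen atoms, gives an at least 2.7-fold lower number from compound 1 to compound 4 (0.43 log units; beyond the scatter). Within the data shown here, the earlier steps all concerned the methoxy group and its replacements, so this is the first sign that this position can also move the read-out, here towards stronger inhibition of growth with the methoxy group still in place. Going by these compounds, the true size of the step stays open, because compound 1 gives only a limit: the limit of > 100000 nM in this assay, at which 2 of the 4 values shown sit.

On these data alone, it also remains open what methylsulfanyl or an amine at this position would give, and methylsulfanyl would help separate the exchange of selenium for sulfur from the loss of the carbon. Whether the same swap lowers the number when hydrogen stands in place of methoxy is equally unknown.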